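This account rests on a few compounds, and the source may have more. Where it says the series, first, only, none or still open, it means among the compounds named here.

Compound 1, `CSc1ccc(CNC(=O)c2ccc(C(C)(C)C)cc2)cc1`: 100 nM
Compound 2, `O=C(O)c1ccc(CNC(=O)c2ccc(-c3ccccc3)cc2)cc1`: 440 nM
Compound 3, `CC(C)(C)c1ccc(C(=O)NCc2ccc(C(=O)O)c(Cl)c2)cc1`: 8.8 nM

All three numbers come from an assay on HeLa cells with Bile acid receptor (Homo sapiens) as the target, read by a luciferase reporter, with a stated time of 24 h; a lower number here means that less compound is needed, a higher number that more compound is needed for the effect. Among them, compound 1 sits second highest: compound 2 gives a higher number and compound 3 a lower one, and both gaps lie beyond the usual scatter. The unmeasured compound 4, `CC(C)(C)c1ccc(C(=O)NCc2ccc(CCC(=O)O)cc2)cc1`, differs from compound 1 in one spot: 2-carboxyethyl in place of methylsulfanyl on an aromatic carbon. For the measured compounds named here, no measured pair differs in exactly this way, so the size of the step cannot be read from the data. The other two compounds point in opposite directions, since compound 3 gives 8.8 nM while compound 2 gives 440 nM. A modest move toward a lower number is expected, a 1.7-fold lower number from compound 1 to compound 4 (0.22 log units; within the scatter). For compound 4 the estimate in this assay is 60 nM, with a range from 15 nM to 300 nM.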

Compound 4, half-maximal effective concentration: 350 nM
Estimate against measurement, compound 4: 5.8-fold (0.77 log units) below, and the stated range ends below it.
By their numbers in this assay, from the lowest: compound 3; then compound 1; then compounds 4 and 2 (each within the scatter of the next).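

At this position, on an aromatic carbon para to a large group, replacing methylsulfanyl with 2-carboxyethyl gives a 3.5-fold higher number from compound 1 to compound 4 (0.54 log units; beyond the scatter) in this assay and so more compound is needed for the effect. For the compounds shown here, this is the first step in the set that isolates a single change, as the earlier compounds differ from one another in more than one place. Nothing available explains the rise.

On these data alone, whether an amine or a longer chain at this position would raise or lower the number remains open. So does whether this step keeps its size on a core carrying a second change.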